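The source may hold more compounds than are shown below. What is called first, only, known or untested is meant among the compounds shown, and "the series" means these compounds.

Going by the values given here, in a functional assay on NCI-H522 cells (Homo sapiens) for cytotoxicity, with a stated time of 3 days (a lower number here means a stronger inhibitor, a higher number a weaker inhibitor), compound 1 `C#Cc1nc2ccccc2[se]1` gives 2170 nM while compound 2 `C#Cc1nc2ccccc2s1` gives 860 nM as the only other number so far. Compound 1 therefore holds the higher of the two numbers, which makes it the weaker inhibitor of the pair, and the gap between them lies beyond the usual scatter of repeat measurements.

Compound 3 `c1ccc2[se]cnc2c1` has not yet been measured. It differs from compound 1 by a single change, hydrogen in place of ethynyl on an aromatic carbon. Among the compounds with values here, both measured compounds carry the ethynyl group, so no measurement yet shows what happens without it, and any forecast here is a loose judgement. The expectation is a clear move towards weaker inhibition in this assay that goes well beyond the scatter, not a result that stays level with compound 1. The expected step (a 6.9-fold higher number from compound 1 to compound 3 (0.84 log units; beyond the scatter)) is a rough estimate. Compound 3 is estimated at 15000 nM with a likely range of 5000 nM to 60000 nM across repeat measurements.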

Compound 3, half-maximal inhibitory concentration: > 40000 nM
Compound 3 ended at the assay's limit; the forecaster's own chance of this, stated with the estimate: 30%; middle value at least 2.6-fold (0.42 log units) away from the limit.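

In this assay compound 3 gives > 40000 nM, which is a limit of the assay and not a number. Both earlier compounds carried the ethynyl group, so they could not show what this group contributes; putting hydrogen in its place, on the aromatic carbon next to the ring nitrogen and next to the ring selenium, now gives an at least 18-fold higher number from compound 1 to compound 3 (1.26 log units; beyond the scatter), a large loss of cytotoxic strength for so small a change. The full size of this step cannot be read, and it can be given only as a bound because compound 3 stands at the end of what the assay reports: the limit of > 40000 nM in this assay, at which 1 of the 3 values shown sits.

The compounds shown leave open whether ethynyl in particular is needed on this carbon, or whether another small group, such as a nitrile, a methyl or an amine, would keep the strength of compound 1. They also leave open whether hydrogen in place of ethynyl would cost as much on the core of compound 2.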